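A Ring Oxygen Enters the Butoxy Chain of Compound 1

The source may hold more compounds than are shown below. What is called first, only, known or untested is meant among the compounds shown, and "the series" means these compounds.

The study covers two measured compounds and one that awaits measurement in an assay on cells with melanin-concentrating hormone receptor 1 (Homo sapiens) as the target, read by radioligand binding; a lower number here means a stronger inhibitor, a higher number a weaker inhibitor. Within the data shown here, compound 1 `CCCCOc1cccc2ccc(N)nc12` is the only one to yield a number: in this assay compound 1 gives 789 nM. Compound 2 `CC(CC(C)(C)C)Oc1cccc2ccc(N3CCCC3)nc12` carries a branched chain and a cyclic amine on the shared core, and in this assay compound 2 returns only a limit of > 2000 nM, which is not a number; the limit of > 2000 nM in this assay, at which 1 of the 2 values shown sits, records where it sits. Compound 1 therefore stands alone as the single numbered point, with nothing measured to rank it against.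

Compound 3 `Nc1ccc2cccc(OCC3CCCO3)c2n1` has not yet been tested. It differs from compound 1 in one place: oxolan-2-yl in place of propyl on a saturated chain carbon bound to an oxygen on an aromatic ring. The entering group brings a five-membered ring with a hydrogen-bond acceptor where the leaving propyl had none. Among the measured compounds shown here, no measured pair shows how such a change behaves here, so the expectation rests on the change alone: a step expected to stay within the scatter, a 1.1-fold higher number from compound 1 to compound 3 (0.06 log units; within the scatter), in this assay. Compound 3 is accordingly estimated at 900 nM in this assay, with a range from 300 nM to 2500 nM.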

Compound 3, half-maximal inhibitory concentration: > 2000 nM
Compound 3: no number, only a limit; the forecaster's own chance of this, stated with the estimate: 20%; middle value at least 2.2-fold (0.34 log units) away from the limit.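

On the saturated chain carbon bound to an oxygen on an aromatic ring, the exchange of propyl for oxolan-2-yl proves not to be a neutral one in this assay, where it gives an at least 2.5-fold higher number from compound 1 to compound 3 (0.40 log units; beyond the scatter). Among these compounds, this is the first step between two compounds that differ in one place, so it is the first direct sign that this place in the chain responds to what is attached there; the earlier compounds, which differ in more than one place, could not show that. The reading of compound 3 is a limit and not a number, and it is the same limit that compound 2 returns: the limit of > 2000 nM in this assay, at which 2 of the 3 values shown sit.

Among the compounds shown here, the true size of the step therefore stays open, as the limit fixes only its lower end, and the single change cannot say whether the five-membered ring or its oxygen carries the loss. A cyclopentyl group in the same place would bear on that question, as would an open methoxyethyl chain, and a longer plain chain would show how much room this place allows.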